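Hydroxy to chloro on the aryl ketone ring of compound 2

The compounds below may be only part of what the source reports. "The series", "measured", "known", "first", "only" and "open" are said of these compounds alone.

Compound 1 `COc1ccc(C(=O)/C=C/c2cc3ccccc3[nH]c2=O)cc1` gives 2380 nM in a functional assay on MDA-MB-468 cells (Homo sapiens) for cytotoxicity, read by sulforhodamine B assay, with a stated time of 24 h; a higher number here means a weaker inhibitor of growth, a lower number a stronger inhibitor of growth. Compound 2 `O=C(/C=C/c1cc2ccccc2[nH]c1=O)c1ccc(O)cc1` gives 2120 nM in this assay and stands lowest of the two numbers shown, though a 1.1-fold lower number from compound 1 to compound 2 (0.05 log units; within the scatter) keeps it within the scatter of compound 1. Compound 3 `O=C(/C=C/c1cc2ccccc2[nH]c1=O)c1ccc(Cl)cc1` differs from compound 2 by chloro in place of hydroxy on an aromatic carbon, on an aromatic carbon of a six-membered aromatic ring of carbon only, para to a large group. Within the data shown here, the only measured step on this ring, from compound 1 to compound 2, stayed within the scatter; no measured step swaps hydroxy for chloro. A step within the scatter is therefore expected in this assay, a 1.1-fold lower number from compound 2 to compound 3 (0.03 log units; within the scatter). Compound 3 is estimated at 2000 nM, range 700 nM to 6000 nM.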

Compound 3, concentration for 50% growth inhibition: 2960 nM
Beside the measured number, compound 3's estimate is 1.5-fold (0.17 log units) below it; the range from low to high includes it.
By their numbers in this assay, from the lowest: compounds 2, 1 and 3 (each within the scatter of the next).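

Chloro in place of hydroxy, para to a large group, gives a 1.4-fold higher number from compound 2 to compound 3 (0.14 log units; within the scatter) in this assay and a 1.2-fold higher number from compound 1 to compound 3 (0.09 log units; within the scatter) with chloro in place of methoxy. Replacing hydroxy, with its hydrogen-bond donor and acceptor, by chloro, with neither, therefore leaves the number within the scatter, something the earlier step between the two oxygen-linked groups could not show. No supporting evidence bears on why these numbers stay so close.

On these data alone, whether an amine, a carboxylic acid or a longer chain at this position would move the number beyond the scatter remains open. So does the effect of changes elsewhere on the shared core.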